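The source may hold more compounds than are shown below. What is called first, only, known or untested is meant among the compounds shown, and "the series" means these compounds.

Measured so far:
compound 1, `Cc1n[nH]c2ccc(-c3nc4cnc(N5CCN(C)CC5)cn4c3Nc3cccc(F)c3)cc12`, gives 18.5% in a functional assay on MV4-11 cells (Homo sapiens) for inhibition, with a stated time of 120 h, tested at 10 uM; a higher number here means more inhibition at the concentration tested (going by the name of the read-out), a lower number less inhibition;
compound 2, `COc1ccc(Nc2c(-c3ccc4[nH]nc(C)c4c3)nc3cnc(N4CCN(C)CC4)cn23)cc1`, gives 3.32% in this assay.

Of these two numbers, compound 2 holds the lower one; its nearest neighbour is compound 1, and the gap between them, a number 15.2 percentage points lower from compound 1 to compound 2 (beyond the scatter), lies beyond the usual scatter. The two share one core and differ only in the group on a nitrogen on an aromatic ring: 3-fluorophenyl in compound 1, 4-methoxyphenyl in compound 2.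

Compound 3, `Cc1n[nH]c2ccc(-c3nc4cnc(N5CCN(C)CC5)cn4c3Nc3cc(Cl)ccc3Cl)cc12`, has not yet been measured. It differs from compound 2 as follows: 2,5-dichlorophenyl in place of 4-methoxyphenyl on a nitrogen on an aromatic ring. So a halogen-bearing phenyl again replaces the methoxyphenyl, as in compound 1, though with two chlorines rather than one fluorine.

Among the measured compounds shown here, only one measured step bears on this, namely a number 15.2 percentage points lower from compound 1 to compound 2 (beyond the scatter), which is of modest size. Reading it in reverse, a return to a halogenated phenyl is expected to raise the number, though with two chlorines the size is uncertain. The step is therefore expected to be a number 11.7 percentage points higher from compound 2 to compound 3 (beyond the scatter). Compound 3 is estimated at 15%, in a range from 0% to 35%.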

Compound 3, a percentage reported as inhibition, at one concentration (the size of the read-out at that concentration, not a potency): 23.8%
The estimate for compound 3 lay 8.8 percentage points below the measured number; low and high end bracket the measured number.
By their numbers in this assay, from the lowest: compound 2; then compounds 1 and 3 (each within the scatter of the next).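

In this assay, replacing the 4-methoxyphenyl on this nitrogen with 2,5-dichlorophenyl gives a number 20.5 percentage points higher from compound 2 to compound 3 (beyond the scatter), which shows that the low number of compound 2 is not shared by a second halogen-bearing phenyl. The two halogenated groups cannot be told apart here, as the step of a number 5.3 percentage points higher from compound 1 to compound 3 (within the scatter) shows, so going from one fluorine to two chlorines, with their different placing on the ring, makes no readable difference at this position; among these three compounds, both halogen-bearing phenyls stand beyond the scatter above the methoxy compound, and no compound shown goes against that. No measurement at hand explains why the number moves with this change.

From the compounds shown here alone, with a single methoxy compound, it remains open whether the lower number goes with the methoxy group itself or with its place on the ring, and a 3-methoxyphenyl would separate those two readings. Also open, going by these compounds, is how a plain phenyl without any substituent, or a saturated ring such as cyclohexyl, would read on this nitrogen.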